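Compound 2 to Compound 3: Ethoxycarbonyl to Carboxy, Untested

The source may hold more compounds than are shown below. What is called first, only, known or untested is meant among the compounds shown, and "the series" means these compounds.

Compound 1 `CCOC(=O)c1cc2ccc(OCc3ccccc3)cc2oc1=O` and compound 2 `CCOC(=O)c1cc2ccc(OCc3ccc(Cl)c(Cl)c3)cc2oc1=O` share one core and were both tested in an in vitro assay on BTI-TN-5B1-4 cells for inhibition of Amine oxidase [flavin-containing] B (Homo sapiens), read by fluorescence, with a stated time of 15 min; a higher number here means a weaker inhibitor, a lower number a stronger inhibitor. In this assay compound 1 gives 7.01 nM, and compound 2 gives 9.47 nM. Among the compounds with values here, the single measured step, a 1.4-fold higher number from compound 1 to compound 2 (0.13 log units; within the scatter), concerns only the aryl group on the saturated chain carbon bound to an oxygen. Compound 2 holds the highest of the two numbers, but its gap to compound 1 is within the scatter, so the two read alike. Compound 3 `O=C(O)c1cc2ccc(OCc3ccc(Cl)c(Cl)c3)cc2oc1=O` differs from compound 2 by hydrogen in place of ethyl on an oxygen next to a carbonyl group, cut one bond further out ethoxycarbonyl to carboxy. Within the data shown here, no measured step touches this part of the molecule; the step from compound 1 to compound 2 says nothing about it. The estimate therefore rests on the value of compound 2 alone and carries a wide range. The expected step is an 11-fold higher number from compound 2 to compound 3 (1.02 log units; beyond the scatter). Compound 3 is expected to give 100 nM in this assay, within a range from 10 nM to 1500 nM.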

Compound 3, half-maximal inhibitory concentration: 410 nM
Compound 3: middle estimate off by 4.1-fold (0.61 log units), on the low side; low and high end bracket the measured number.
By their numbers in this assay, from the lowest: compounds 1 and 2 (each within the scatter of the next); then compound 3.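

In this assay, hydrogen in place of ethyl on an oxygen next to a carbonyl group, which turns ethoxycarbonyl into carboxy, gives a 43-fold higher number from compound 2 to compound 3 (1.64 log units; beyond the scatter). Within the data shown here, this position therefore responds far more strongly than the aryl group, where the only earlier step, a 1.4-fold higher number from compound 1 to compound 2 (0.13 log units; within the scatter), did not separate the two compounds. No measurement shown here accounts for the size of the new step.

The compounds shown leave open whether a methyl ester, a longer chain in place of ethyl or a primary amide in place of ethoxycarbonyl would stay close to compound 2 or fall nearer to compound 3. They also leave open whether the same change made on compound 1, which carries phenyl rather than 3,4-dichlorophenyl, would produce a step of similar size.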